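Benzyl Group Swap and Cytotoxicity in Two Measured Analogues

The compounds below may be only part of what the source reports. "The series", "measured", "known", "first", "only" and "open" are said of these compounds alone.

Compound 1 `Cc1cc(C)c(Oc2cc(Nc3ccc(C#N)cc3)ncc2C(=O)NCc2cn(Cc3ccccc3F)nn2)c(C)c1`: > 222000 nM in an ADME assay on MT4 cells (Homo sapiens) for cytotoxicity, read by MTT assay, with a stated time of 5 days; on this read-out higher numbers stand for lower toxicity in this test and lower numbers for higher toxicity in this test
Compound 2 `Cc1cccc(Cn2cc(CNC(=O)c3cnc(Nc4ccc(C#N)cc4)cc3Oc3c(C)cc(C)cc3C)nn2)c1`: 114000 nM

The value for compound 1 is a limit of this assay, not a number. Going by the values given here, compound 2 therefore stands as the only compound with a number; the one further value shown for this series is a limit, as recorded in the limit of > 222000 nM in this assay, at which 1 of the 2 values shown sits. Among the compounds with values here, the one measured step is an at least 1.9-fold lower number from compound 1 to compound 2 (0.28 log units; that floor lies within the scatter), and it is drawn from a limit on one side, so its size is only a floor.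

Compound 3 `Cc1cc(C)c(Oc2cc(Nc3ccc(C#N)cc3)ncc2C(=O)NCc2cn(Cc3ccccc3C#N)nn2)c(C)c1` differs from compound 2 by 2-cyanophenyl in place of 3-methylphenyl on a saturated chain carbon bound to an aromatic nitrogen. This change sits at the same place as the measured step, so that step is the only one that bears on it. That step reached at most the edge of the scatter, and nothing shown points to a step of any size in either direction for a nitrile in place of a methyl at this position. Compound 3 is therefore expected to show a step of about a 1.1-fold higher number from compound 2 to compound 3 (0.06 log units; within the scatter), that is, none beyond the scatter. The expected value of compound 3 in this assay is estimated at 130000 nM, with a range from 60000 nM to 280000 nM.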

Compound 3, half-maximal cytotoxic concentration: > 219000 nM
Compound 3: a limit, no number; the forecaster's own chance of this, stated with the estimate: 35%; middle value at least 1.6-fold (0.22 log units) from the limit.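

In this assay compound 3 stands at a limit of the assay, not at a number: the limit of > 219000 nM in this assay, at which 1 of the 3 values shown sits.

The one readable new step is an at least 1.9-fold higher number from compound 2 to compound 3 (0.28 log units; that floor lies within the scatter), so the exchange of 3-methylphenyl for 2-cyanophenyl on this saturated chain carbon is not shown to move the read-out beyond the scatter, and its size is only a floor. Together with the earlier step, this means that three different groups have now been seen at this place, one of them carrying a nitrile, and no readable step among them lies beyond the scatter; the step between compound 1 and compound 3, cyano in place of fluoro on an aromatic carbon, cannot be read, as both compounds stand at limits.

From the compounds shown here alone, how far the true values of compound 1 and compound 3 lie from their limits remains open, and with it the real size of both readable steps. Also open, going by these compounds, is whether any other group at this place would give a step beyond the scatter, such as a phenyl ring carrying an amine or a carboxylic acid, or a longer chain in place of the saturated chain carbon.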